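A few compounds are considered here, and "the series" means these few. Any claim that something is new, unique, unknown or untested is made for them only; others in the source may bear on it.

The measured compounds:
compound 1, `O=C(/C=C\Nc1ccc(O)cc1)c1cn(-c2ccccc2)nc1-c1ccc(F)cc1`, giving 2600 nM in a functional assay on PC-3 cells (Homo sapiens) for antiproliferative activity, read by MTT assay, with a stated time of 48 h; a lower number here means a stronger inhibitor, a higher number a weaker inhibitor
compound 2, `COc1ccc(N/C=C\C(=O)c2cn(-c3ccccc3)nc2-c2ccc(F)cc2)cc1`, giving 4600 nM
compound 3, `COc1cc(-c2nn(-c3ccccc3)cc2C(=O)/C=C\Nc2ccc(O)cc2)cc(OC)c1OC`, giving 4600 nM

Compound 1 and compound 2 differ by methyl in place of hydrogen on an oxygen on an aromatic ring, and that step gave a 1.8-fold higher number from compound 1 to compound 2 (0.25 log units; within the scatter). Compound 3 carries a different core; how it differs from the core of compound 1 is not broken down here. At the digits reported, compound 3 and compound 2 stand level, and neither can be ordered against the other.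

Compound 4, `COc1ccc(N/C=C\C(=O)c2cn(-c3ccccc3)nc2-c2cc(OC)c(OC)c(OC)c2)cc1`, has not yet been measured. It differs from compound 3 by methyl in place of hydrogen on an oxygen on an aromatic ring, the same change as that between compound 1 and compound 2, made at a place described in identical words. Because that earlier step gave a 1.8-fold higher number from compound 1 to compound 2 (0.25 log units; within the scatter), a step of about the same size is expected here, a 1.7-fold higher number from compound 3 to compound 4 (0.24 log units; within the scatter). On that basis compound 4 is estimated at 8000 nM, expected to fall between 4000 nM and 16000 nM.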

Compound 4, half-maximal inhibitory concentration: 9600 nM
Estimate against measurement, compound 4: 1.2-fold (0.08 log units) below, and the stated range covers the measured number.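

Methyl in place of hydrogen on the oxygen gave a 2.1-fold higher number from compound 3 to compound 4 (0.32 log units; beyond the scatter) in this assay, and this step matches the one on the other core: the same change on two cores in this assay, a 1.8-fold higher number (0.25 log units; within the scatter) from compound 1 to compound 2 and a 2.1-fold higher number (0.32 log units; beyond the scatter) from compound 3 to compound 4, 1.2-fold (0.07 log units) apart, within the scatter of two such steps. Placing 3,4,5-trimethoxyphenyl where 4-fluorophenyl stood gave a 2.1-fold higher number from compound 2 to compound 4 (0.32 log units; beyond the scatter), a separate change at another place. The hydroxy to methoxy change thus carried across these two cores at about one size, but two cores in a single assay do not show that it would hold across the series, and they do not show why the number moves.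

The compounds shown leave open what a longer chain on that oxygen, or an amine in place of the hydroxy group, would do. From the compounds shown here alone, whether a carboxylic acid at that place would follow the same trend also remains open.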